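Amide substituent change on a shared core: expectation for compound 3

The source may report more compounds than this note shows. Statements on the series, on what has been measured and on what is new or still open speak of the compounds shown alone.

Compound 1 `Cc1nc(S(C)(=O)=O)ccc1Oc1ncnc(OC2CCN(C(=O)OC(C)(C)C(F)(F)F)CC2)c1F`: 6.53 nM
Compound 2 `Cc1nc(S(C)(=O)=O)ccc1Oc1ncnc(OC2CCN(C(=O)C3CCCC3)CC2)c1F`: 72.8 nM

In a functional assay on isolated protein for inhibition of Glucose-dependent insulinotropic receptor (Homo sapiens), read by HTRF and cAMP accumulation (on this read-out higher numbers stand for an effect only at larger amounts of compound and lower numbers for an effect already at smaller amounts), compound 1 gives 6.53 nM and compound 2 gives 72.8 nM. Compound 2 stands highest of the two numbers shown; the only step, an 11-fold higher number from compound 1 to compound 2 (1.05 log units; beyond the scatter), is large and beyond the scatter.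

Compound 3 `Cc1nc(S(C)(=O)=O)ccc1Oc1ncnc(OC2CCN(C(=O)c3nc(C(C)(C)F)no3)CC2)c1F` differs from compound 2 in one place: a group of 9 heavy atoms (5 carbon, 2 nitrogen, 1 oxygen, 1 fluorine; one five-membered aromatic ring with 3 hetero atoms) in place of a group of 5 heavy atoms (5 carbon; one five-membered non-aromatic ring of carbon only), on a carbonyl carbon. Within the data shown here, the sole measured step bears on the same carbonyl carbon, yet swaps a different pair of groups, so it shows only that this position moves the read-out strongly; its direction cannot be carried over. Since compound 1 with the 1-methyl-1-(trifluoromethyl)ethoxy group gave 6.53 nM, a return toward that range is conceivable, but not established. Compound 3 is therefore expected to give a number between those two, a 3.6-fold lower number from compound 2 to compound 3 (0.56 log units; beyond the scatter), estimated at 20 nM with a wide range from 5 nM to 90 nM.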

Compound 3, half-maximal effective concentration: 43.4 nM
Compound 3: middle estimate off by 2.2-fold (0.34 log units), on the low side, within the range that was stated.
By their numbers in this assay, from the lowest: compound 1; then compounds 3 and 2 (each within the scatter of the next).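

In this assay, the aromatic five-membered ring with 3 hetero atoms on the carbonyl carbon cannot be told apart from cyclopentyl, with a 1.7-fold lower number from compound 2 to compound 3 (0.22 log units; within the scatter). The same group stays clearly separated from the 1-methyl-1-(trifluoromethyl)ethoxy group, with a 6.6-fold higher number from compound 1 to compound 3 (0.82 log units; beyond the scatter), so among these three compounds, the two ring-bearing groups both give higher numbers than the open-chain group of compound 1. Nothing at hand accounts for this result.

The compounds shown leave open whether the low number of compound 1 goes with the oxygen on the carbonyl carbon or with the three fluorines, a question that a plain tert-butoxy group would address. They also leave open what the fluorine on the aromatic ring's side chain contributes, which an isopropyl group in its place would test.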